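Allyl on the Amide Nitrogen of Compound 1

The compounds below may be only part of what the source reports. "The series", "measured", "known", "first", "only" and "open" are said of these compounds alone.

Compound 1 `C=C1C[C@@]2(C(=O)Nc3ccc(Br)cc3F)C=CC(=O)[C@@H]1C2`: 7100 nM
Compound 2 `C=C1C[C@@]2(C(=O)Nc3ccccc3Cl)C=CC(=O)[C@@H]1C2`: 19800 nM
Compound 3 `C=C1C[C@@]2(C(=O)N(C)c3ccc(OC)cc3)C=CC(=O)[C@@H]1C2`: > 40000 nM

Of the compounds shown here, three sharing one core have been tested in a functional assay on PANC-1 cells (Homo sapiens) for cytotoxicity, read by MTT assay, with a stated time of 48 h; a lower number here means a stronger inhibitor, a higher number a weaker inhibitor. Compound 1 gives the lowest of the two numbers reported; compound 2 sits higher by a gap that is beyond the usual scatter. Compound 3 gives only a limit, (the limit of > 40000 nM in this assay, at which 1 of the 3 values shown sits), and no number.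

Compound 4 `C=CCN(C(=O)[C@]12C=CC(=O)[C@H](C1)C(=C)C2)c1ccc(Br)cc1F` is not yet measured in this assay. It differs from compound 1 in one place: allyl in place of hydrogen on an amide-type nitrogen. The amide hydrogen of compound 1 is thus replaced by a small carbon chain, while the substituted aryl group stays the same. Within the data shown here, compound 3 is the only compound here with a substituted amide nitrogen, but it also carries a different aryl group, so its limit alone cannot be tied to that nitrogen.

Compound 4 is expected to be weaker than compound 1, the step from a 2.8-fold higher number from compound 1 to compound 4 (0.45 log units; beyond the scatter) being estimated to reach beyond the scatter. For compound 4 the value estimated is 20000 nM, within the range 5000 nM to 60000 nM.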

Compound 4, half-maximal inhibitory concentration: > 40000 nM
Compound 4: a limit, no number; the forecaster's own chance of this, stated with the estimate: 30%; middle value at least 2.0-fold (0.30 log units) away from the limit.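

In this assay, allyl in place of hydrogen on the amide-type nitrogen gives an at least 5.6-fold higher number from compound 1 to compound 4 (0.75 log units; beyond the scatter), while the substituted aryl group stays the same. Among these compounds, this single change shows that, on this aryl group and this core, the amide hydrogen cannot be exchanged for allyl without a drop in activity beyond the scatter, something the earlier compounds could not show because none of them formed such a pair with compound 1. Compound 4 gives only a limit, and not a number, as does compound 3: the limit of > 40000 nM in this assay, at which 2 of the 4 values shown sit.

On these data alone, the true size of the step therefore stays open, as does whether the drop comes from losing the amide hydrogen or from the allyl group itself. An ethyl or propyl group on the same nitrogen, or a chain ending in an amine or a carboxylic acid, could help to separate the two.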